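The source may report more compounds than this note shows. Statements on the series, on what has been measured and on what is new or still open speak of the compounds shown alone.

Measured so far:
compound 1, `O=C(CI)NCCCNc1ncnc2c1ncn2[C@@H]1O[C@H](COP(=O)(O)OP(=O)(O)OP(=O)(O)O)[C@@H](O)[C@H]1O` — in an assay on isolated protein for inhibition of hexokinase-3 (Rattus norvegicus), with a stated time of 6 h, tested at 10 mM (a higher number here means more inhibition at the concentration tested (going by the name of the read-out), a lower number less inhibition), compound 1 gives 0%
compound 2, `O=C(CI)NCCCCCCC(=O)NCCCNc1ncnc2c1ncn2[C@@H]1O[C@H](COP(=O)(O)OP(=O)(O)OP(=O)(O)O)[C@@H](O)[C@H]1O` — in this assay compound 2 gives 0%

Compound 1 stands level with compound 2 at the digits shown; its nearest neighbour is compound 2, and the one measured step, no change at the digits printed from compound 1 to compound 2 (within the scatter), lies within the scatter. That step is the only one recorded, and it swaps 5-(((iodomethyl)carbonyl)amino)pentyl for iodo on a saturated chain carbon bound to a carbonyl carbon without moving the read-out.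

Compound 3, `CC(=O)NCCCCCCCCNc1ncnc2c1ncn2[C@@H]1O[C@H](COP(=O)(O)OP(=O)(O)OP(=O)(O)O)[C@@H](O)[C@H]1O`, has not yet been measured in this assay. It differs from compound 1 by 5-acetamidopentyl in place of ((iodomethyl)carbonyl)amino on a saturated chain carbon, three bonds along the chain from a nitrogen on an aromatic ring. The change sits on a saturated chain carbon, three bonds along the chain from a nitrogen on an aromatic ring, and is therefore of the same kind as the measured step, an extension of the same side chain with the iodine removed. Since the measured step from compound 1 to compound 2 showed no change, the expectation is a step of no change at the digits printed from compound 1 to compound 3 (within the scatter), that is, none beyond the scatter. Compound 3 is therefore estimated at 0%, with a range from 0% to 10%.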

Compound 3, a percentage reported as inhibition, at one concentration (the size of the read-out at that concentration, not a potency): 0%
For compound 3 middle estimate and measured number coincide at the digits printed, within the range that was stated.
By their numbers in this assay, from the lowest: compounds 1, 2 and 3 (each within the scatter of the next).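

In this assay, among the compounds shown here, the new comparison reads no change at the digits printed from compound 1 to compound 3 (within the scatter), and it is the first to take the iodine away: compound 1 and compound 2 both carry the ((iodomethyl)carbonyl)amino end, whereas compound 3 ends in 5-acetamidopentyl at the saturated chain carbon, three bonds along the chain from a nitrogen on an aromatic ring. Within these compounds, then, neither a chain end with iodine nor one without it separates from the other on this read-out, and since all three sit at the same printed level, no group at this position is yet tied to any inhibition. Nothing available bears on why the read-out holds at this level.

Because the step from compound 1 to compound 3 alters chain length and end group in one move, the effect of the iodine alone at a fixed chain length stays unresolved. Also open, as far as these compounds go, is whether a different end on this chain, such as a primary amine or a carboxylic acid, or a still longer chain, would give any inhibition in this assay at all.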